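The source may hold more compounds than are shown below. What is called first, only, known or untested is meant among the compounds shown, and "the series" means these compounds.

Compound 1 `CCCc1ncc2cnnc(O)n12`: in a functional assay for inhibition, with Homo sapiens as the target (a higher number here means a weaker inhibitor, a lower number a stronger inhibitor), compound 1 gives > 48000 nM, which is a limit of the assay and not a number.
Compound 2 `C=CCSc1nncc2cnc(COC)n12`: in this assay compound 2 gives 79000 nM.
Compound 3 `CCCc1ncc2cnnc(SC)n12`: in this assay compound 3 gives > 48000 nM, again a limit of the assay.

Compound 3 therefore stands only at a limit; it is one of the two values that sit there (the limit of > 48000 nM in this assay, at which 2 of the 3 values shown sit). Going by the values given here, the one measured step, a step that the two limits leave unreadable from compound 1 to compound 3, runs between two limits, so its size cannot be read. Compound 4 `COCc1ncc2cnnc(SC)n12` is still to be measured. It differs from compound 3 by methoxy in place of ethyl on a saturated chain carbon bound to an aromatic carbon. Among the compounds with values here, no measured step concerns this change of the chain, so nothing read so far says how large a step to expect or in which direction. Compound 2, which carries the methoxymethyl chain with another group on the shared core, gives a weak number close to where the limits sit. Compound 4 is therefore expected to stay weak, with an estimated step that the limit leaves unreadable from compound 3 to compound 4 that is not expected to go beyond the scatter. The estimate for compound 4 in this assay is 65000 nM, between 25000 nM and 160000 nM.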

Compound 4, half-maximal inhibitory concentration: > 48000 nM
Compound 4 ended at the assay's limit; the forecaster's own chance of this, stated with the estimate: 55%; the middle value does not contradict the limit.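

In this assay compound 4 gives > 48000 nM, a limit of the assay. Its steps from compound 2 and from compound 3 therefore cannot be read. The compounds shown leave open whether methoxymethyl in place of propyl changes inhibition at all.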